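The source may report more compounds than this note shows. Statements on the series, on what has been measured and on what is new or still open speak of the compounds shown alone.

Measured compounds in an assay on isolated protein for inhibition of Nitric oxide synthase, inducible (Homo sapiens), read by scintillation counting, with a stated time of 30 min, tested at 50 uM; a lower number here means less inhibition, a higher number more inhibition at the concentration tested (going by the name of the read-out):
compound 1, `COc1ccc(N)c(C2=NN(C(C)=O)C(C)(C)S2)c1`, 77.1%
compound 2, `CCC(=O)N1N=C(c2cc(OC)ccc2N)SC1(C)C`, 73%
compound 3, `COc1ccc(N)c(C2=NN(C(=O)C3CCCCC3)C(C)(C)S2)c1`, 100%

Compound 1 stands second highest of the three numbers in this assay. Its nearest neighbour is compound 2, and the step of a number 4.1 percentage points lower from compound 1 to compound 2 (within the scatter) is within the scatter, so the two are not distinguished. Its furthest neighbour is compound 3, and the step of a number 22.9 percentage points higher from compound 1 to compound 3 (beyond the scatter) is beyond the scatter; the related step of a number 27 percentage points higher from compound 2 to compound 3 (beyond the scatter) points the same way. Both of these larger steps change the group on the carbonyl carbon and leave the aromatic ring untouched.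

Compound 4, `CC(=O)N1N=C(c2cc(Cl)ccc2N)SC1(C)C`, has not been measured. It differs from compound 1 by chloro in place of methoxy on an aromatic carbon. Among the measured compounds shown here, none of the measured steps alters anything on the aromatic ring; all three vary the acyl side, so no measured step bears directly on this change. For the measured compounds named here, with no comparable step in hand, the expectation for compound 4 rests on compound 1 alone, and the change is expected to give no step beyond the scatter, the estimated step being a number 3.1 percentage points lower from compound 1 to compound 4 (within the scatter). Compound 4 is therefore estimated at 74% in this assay, with a range from 50% to 95%.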

Compound 4, a percentage reported as inhibition, at one concentration (the size of the read-out at that concentration, not a potency): 72.8%
Beside the measured number, compound 4's estimate is 1.2 percentage points above it, within the range that was stated.
By their numbers in this assay, from the lowest: compounds 4, 2 and 1 (each within the scatter of the next); then compound 3.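

In this assay, among the compounds shown here, the step of a number 4.3 percentage points lower from compound 1 to compound 4 (within the scatter) is the first reading of any change on the aromatic ring, and it shows that chloro in place of methoxy, at this place meta to a large group and para to an amino group, gives a number not distinguished from that of the parent. Methoxy brings one more heavy atom than chloro and a hydrogen-bond acceptor that chloro lacks, yet this exchange leaves no difference that the read-out can separate. Among the compounds shown, the steps beyond the scatter are still those on the carbonyl carbon, such as a number 22.9 percentage points higher from compound 1 to compound 3 (beyond the scatter), while this first change on the ring stays within it.

For the compounds shown here, whether an amine, a carboxylic acid or a longer alkoxy chain at the same place would also stay within the scatter remains open, since methoxy and chloro are the only two groups seen there. Also open, as far as these compounds go, is whether chloro would behave in the same way with the cyclohexyl group of compound 3 on the carbonyl carbon, or at another carbon of the ring. Nothing measured here speaks to why the number holds across this exchange.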